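A hydroxyl replacing a ketone on the cyclohexyl ring

A few compounds are considered here, and "the series" means these few. Any claim that something is new, unique, unknown or untested is made for them only; others in the source may bear on it.

Of the compounds shown here, three that share one core have been tested in an assay for inhibition of Indoleamine 2,3-dioxygenase 1 (Homo sapiens), with a stated time of 1 h, tested at 10 uM; on this read-out higher numbers stand for more inhibition at the one concentration tested (going by the name of the read-out) and lower numbers for less inhibition. Compound 1 `Oc1cccc(CNc2cc(Br)cc3[nH]ncc23)c1` gives 45%. Compound 2 `ONc1cccc(CNc2cc(Br)cc3[nH]ncc23)c1` gives 53%. Compound 3 `O=C1CCCC(Nc2cccc(CNc3cc(Br)cc4[nH]ncc34)c2)C1` gives 52%. All three numbers lie within the scatter of one another: the step of a number 8 percentage points higher from compound 1 to compound 2 (within the scatter), the step of a number 7 percentage points higher from compound 1 to compound 3 (within the scatter) and the step of a number 1 percentage points lower from compound 2 to compound 3 (within the scatter) are each no more than repeated measurements would show. Compound 3 thus stands among its neighbours, with compound 2 nearest and compound 1 furthest, and neither apart from it.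

Compound 4 `OC1CCCC(Nc2cccc(CNc3cc(Br)cc4[nH]ncc34)c2)C1` has not been measured. It differs from compound 3 in one place: 3-hydroxycyclohexyl in place of 3-oxocyclohexyl on a nitrogen on an aromatic ring. For the measured compounds named here, no measured step exchanges a carbonyl for a hydroxyl, so the nearest guide is the step of a number 1 percentage points lower from compound 2 to compound 3 (within the scatter), in which a quite different group entered at the same nitrogen and the number stayed within the scatter. The step of no change at the digits printed from compound 3 to compound 4 (within the scatter) is therefore expected to stay within the scatter, with no clear direction. Compound 4 is estimated to give 52% in this assay, between 38% and 66%.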

Compound 4, a percentage reported as inhibition, at one concentration (the size of the read-out at that concentration, not a potency): 52%
Beside the measured number, compound 4's estimate shows no gap at the digits printed, within the range that was stated.
By their numbers in this assay, from the lowest: compounds 1, 3, 4 and 2 (each within the scatter of the next).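

In this assay, for the compounds shown here, exchanging the ketone of 3-oxocyclohexyl for the hydroxyl of 3-hydroxycyclohexyl on this nitrogen gives no change at the digits printed from compound 3 to compound 4 (within the scatter) and adds a hydrogen-bond donor, so this is the first change made on the cyclohexyl ring itself and the number does not respond to it. The comparisons with the smaller groups agree, with a number 1 percentage points lower from compound 2 to compound 4 (within the scatter) and a number 7 percentage points higher from compound 1 to compound 4 (within the scatter) showing that this ring with a hydroxyl also stays within the scatter of both. No measurement is available to explain why these numbers hold together.

Whether any group on this ring can shift the number remains open, as an amine or a carboxylic acid in place of the hydroxyl is not among the compounds shown. Also unanswered is whether a longer chain in place of the ring would behave the same way.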